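The source may report more compounds than this note shows. Statements on the series, on what has been measured and on what is new or still open speak of the compounds shown alone.

Of the compounds shown here, three have been measured so far. Compound 1 `COc1ccccc1NC(=O)c1ccc(OCCCN2CCN(c3ccccc3OC)CC2)cc1` gives 79.4 nM in an assay on Prostate gland (Oryctolagus cuniculus) for inhibition of Adrenergic receptor alpha-1 (Homo sapiens); a lower number here means tighter binding, a higher number weaker binding. Compound 2 `COc1ccccc1N1CCN(CCCOc2ccc(C(=O)Nc3ccccc3OCCCC(=O)O)cc2)CC1` gives 100 nM in this assay, and compound 3 `COc1ccccc1N1CCN(CCCCOc2ccc(C(=O)Nc3ccccc3OCCCC(=O)O)cc2)CC1` gives 79.4 nM in this assay. Compound 2 has the highest of the three numbers, but its distance to compound 1, a 1.3-fold higher number from compound 1 to compound 2 (0.10 log units; within the scatter), is within the scatter, and its gap to compound 3 is of the same small size, so the three stand together.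

Compound 4 `COc1ccccc1N1CCN(CCC(Oc2ccc(C(=O)Nc3ccccc3OCCCC(=O)O)cc2)c2ccc(Br)cc2)CC1` has not yet been measured. It differs from compound 2 in one place: 4-bromophenyl in place of hydrogen on a saturated chain carbon bound to an oxygen on an aromatic ring and a saturated chain carbon. For the measured compounds named here, none of the measured steps touches this place. Going by the values given here, the only step recorded, from compound 1 to compound 2, changes a different carbon of the chain, and it was small, a 1.3-fold higher number from compound 1 to compound 2 (0.10 log units; within the scatter). Compound 2 and compound 3 differ only in the length of that chain, and their numbers lie close together. There is therefore no measured change of this kind to lean on, and the expected step of a 1.3-fold higher number from compound 2 to compound 4 (0.10 log units; within the scatter) is set near zero with a wide margin. Compound 4 is estimated at 125 nM, with a range from 30 nM to 500 nM.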

Compound 4, dissociation constant: 100 nM
For compound 4 the middle estimate is 1.3-fold (0.10 log units) above the measured one; the range from low to high includes it.
By their numbers in this assay, from the lowest: compounds 1, 3, 2 and 4 (each within the scatter of the next).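

In this assay, putting 4-bromophenyl in place of hydrogen on the saturated chain carbon bound to an oxygen on an aromatic ring and a saturated chain carbon gives no change at the digits printed from compound 2 to compound 4 (within the scatter) and so leaves the binding number where it was. The earlier compounds shown here carried only hydrogen on this carbon, so they could not show that it can hold an added group of 7 heavy atoms, including a six-membered aromatic ring, with no change that rises above the scatter of this measurement. Nothing measured here explains this lack of change.

One large group on one carbon says little about other groups at the same place, so a plain phenyl, a methyl or a chain ending in an amine could give the same number or a very different one. As far as these compounds go, it also remains open whether the bromine contributes anything, and whether 4-bromophenyl would behave the same way on the longer chain of compound 3 or in a compound ending without the carboxylic acid.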